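The source may report more compounds than this note shows. Statements on the series, on what has been measured and on what is new or still open speak of the compounds shown alone.

Of the compounds shown here, two built on a shared core have been measured in a functional assay on HEK293 cells for antagonist activity at transient receptor potential cation channel subfamily V member 1 (Rattus norvegicus); on this read-out higher numbers stand for weaker inhibition and lower numbers for stronger inhibition. Compound 1 `CC(C)c1ccc(NC(=O)N2CCN(c3ncccc3Br)CC2)cc1` gives 27.1 nM in this assay, and compound 2 `O=C(Nc1ccc(C(F)(F)F)cc1)N1CCN(c2ncccc2Cl)CC1` gives 81.4 nM, the higher of the two numbers and so the weaker inhibitor, a gap beyond the usual scatter. Compound 3 `O=C(Nc1ccc(Cl)cc1)N1CCN(c2ncccc2Cl)CC1` has not yet been measured. It differs from compound 2 in one place: chloro in place of trifluoromethyl on an aromatic carbon. For the measured compounds named here, no measured pair shows what this exchange does, so nothing points to a change beyond the scatter in either direction. Compound 3 is expected to give an estimated 80 nM, between 30 nM and 250 nM. That expectation means a step of a 1.0-fold lower number from compound 2 to compound 3 (0.01 log units; within the scatter).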

Compound 3, half-maximal inhibitory concentration: 2670 nM
Estimate against measurement, compound 3: 33-fold (1.52 log units) below; measured number outside the range, above it.
By their numbers in this assay, from the lowest: compound 1; then compound 2; then compound 3.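

On the aromatic carbon para to a large group, the choice of substituent matters far more than compound 1 and compound 2 could show, since those two differ in more than one place. In this assay, chloro in place of trifluoromethyl gives a 33-fold higher number from compound 2 to compound 3 (1.52 log units; beyond the scatter), so this exchange is far from a neutral swap at this position. Nothing available here offers a reason for the step.

Still open, on these data alone, is how other groups would behave on this carbon. A nitrile or a methoxy group there would show whether trifluoromethyl is unusual or chloro is.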